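A few compounds are considered here, and "the series" means these few. Any claim that something is new, unique, unknown or untested is made for them only; others in the source may bear on it.

In a functional assay on SK-MEL-28 cells (Homo sapiens) for inhibition, read by MTT assay, with a stated time of 48 h (on this read-out higher numbers stand for weaker inhibition and lower numbers for stronger inhibition), compound 1 (`CS(=O)(=O)c1ccc(-c2nc3ccccn3c2Sc2ccccc2)cc1`) reads 61900 nM and compound 2 (`COc1ccc(-c2nc3ccccn3c2Sc2ccccc2)cc1`) reads 83900 nM with the two lying within the scatter of each other. Compound 3 (`c1ccc(Sc2c(-c3ccccc3)nc3ccc(-c4ccccc4)cn23)cc1`) gives only a limit of the assay at > 100000 nM and no number. Going on to compound 4 (`c1ccc(Sc2c(-c3cccs3)nc3ccccn23)cc1`) puts thiophen-2-yl in place of 4-methoxyphenyl on an aromatic carbon. Only a 1.4-fold higher number from compound 1 to compound 2 (0.13 log units; within the scatter) bears on this, and it exchanges a substituent rather than the ring itself. On that small step, no shift beyond the scatter is expected in this assay and the expected 1.2-fold lower number from compound 2 to compound 4 (0.08 log units; within the scatter) stays modest. Compound 4 is expected at 70000 nM with an estimated range from 30000 nM to 100000 nM in this assay.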

Compound 4, half-maximal inhibitory concentration: 85300 nM
Compound 4: middle estimate off by 1.2-fold (0.09 log units), on the low side; measured number inside the range.
By their numbers in this assay, from the lowest: compounds 1, 2 and 4 (each within the scatter of the next). At a limit, above all of these: compound 3.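

Exchanging the whole aromatic ring at this position, rather than a substituent on it, gives a 1.0-fold higher number from compound 2 to compound 4 (0.01 log units; within the scatter) in this assay. So thiophen-2-yl, with its five-membered ring, reads alike with 4-methoxyphenyl here, and the earlier step, which only exchanged a substituent, could not show this. Compound 3 gives a limit and no number, and the other readings lie not far under that limit: the limit of > 100000 nM in this assay, at which 1 of the 4 values shown sits.

On these data alone, whether an amine or a carboxylic acid on this ring would bring a reading well clear of that limit stays open. So does the role of the phenylsulfanyl group.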